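Ethoxy Replaces Dimethylamino on a Shared Core

This account rests on a few compounds, and the source may have more. Where it says the series, first, only, none or still open, it means among the compounds named here.

Within the data shown here, compound 2 `CCCCCCCCCCCCCCCCCCNC(=O)[C@@H]1CSC(c2ccc(N(C)C)cc2)N1` gives 6000 nM in a functional assay on PC-3 cells (Homo sapiens) for antiproliferative activity, read by sulforhodamine B assay (a lower number here means a stronger inhibitor, a higher number a weaker inhibitor), the lower of the two numbers measured so far. Compound 1 `CCCCCCCCCCCCCCCCCCNC(=O)[C@@H]1CSC(c2ccc(OC)cc2)N1` gives 19000 nM. Among the measured compounds shown here, the one known step, a 3.2-fold lower number from compound 1 to compound 2 (0.50 log units; beyond the scatter), shows that the group on this aromatic carbon moves the number. Compound 3 `CCCCCCCCCCCCCCCCCCNC(=O)[C@@H]1CSC(c2ccc(OCC)cc2)N1` brings (ethoxy in place of dimethylamino on an aromatic carbon). Because compound 1 gives 19000 nM with a methoxy that is joined through oxygen just as ethoxy is, the earlier gain is expected to be largely undone, an estimated step of a 2.5-fold higher number from compound 2 to compound 3 (0.40 log units; beyond the scatter). Compound 3 is therefore expected to give about 15000 nM, within 6000 nM to 40000 nM.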

Compound 3, half-maximal inhibitory concentration: > 20000 nM
Compound 3 gave a limit, no number; the forecaster's own chance of this, stated with the estimate: 10%; at least 1.3-fold (0.12 log units) between middle value and limit.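

Ethoxy in place of dimethylamino gives an at least 3.3-fold higher number from compound 2 to compound 3 (0.52 log units; beyond the scatter), so a second group joined through oxygen also lacks the lower number seen with dimethylamino in compound 2. Adding a methyl to the methoxy of compound 1 gives an at least 1.0-fold higher number from compound 1 to compound 3 (0.02 log units; that floor lies within the scatter), so no order between these two oxygen-linked groups can be read. The result for compound 3 is a limit of the assay, not a number: the limit of > 20000 nM in this assay, at which 1 of the 3 values shown sits.

On these data alone, how a primary amine or a hydroxyl on this aromatic carbon would compare with dimethylamino remains open.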